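The source may hold more compounds than are shown below. What is called first, only, known or untested is meant among the compounds shown, and "the series" means these compounds.

Working notes on the series, starting from compound 1 `C=C1C(=O)[C@@]23C(=O)OC[C@]4(C(=O)CCC(C)(C)[C@H]4C=O)[C@@H]2CC[C@@H]1[C@H]3O`. Going by the values given here, in an ADME assay on L02 cells (Homo sapiens) for cytotoxicity, read by MTT assay, with a stated time of 72 h (a lower number here means a stronger inhibitor, a higher number a weaker inhibitor), compound 1 gives 29700 nM, the only exact number available so far. Compound 2 `C=C1C(=O)[C@@]23C(=O)OC[C@]4([C@@H](OC(C)=O)CCC(C)(C)[C@H]4C=O)[C@@H]2CC[C@@H]1[C@H]3O` has a different substitution on the core and gives only a limit, > 50000 nM. Compound 1 therefore stands alone as a numerical reference point, with no measured neighbour to define a trend.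

Compound 3 `C=C1C(=O)[C@@]23C(=O)OC[C@]4(C(=O)CCC(C)(C)[C@H]4C=O)[C@@H]2CC[C@@H]1[C@H]3OC(=O)CCCCC1CCSS1` keeps the core of compound 1 and changes in one place: a group of 11 heavy atoms (8 carbon, 1 oxygen, 2 sulfur; one five-membered non-aromatic ring with 2 hetero atoms) in place of a hydrogen atom, on an oxygen on a saturated carbon. The new group sits on an oxygen on a saturated carbon, and a five-membered non-aromatic ring with 2 hetero atoms is carried in on it. Among the compounds with values here, no measured pair tests a change at this oxygen, so the expectation rests on the value of compound 1, 29700 nM, and has wide uncertainty. A modest shift toward stronger inhibition is expected in this assay, although a result within the scatter would not be surprising. The estimated step of a 1.9-fold lower number from compound 1 to compound 3 (0.27 log units; within the scatter) is therefore small. For compound 3, the expected value is 16000 nM, with an estimated range of 5000 nM to 45000 nM.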

Compound 3, half-maximal inhibitory concentration: 19900 nM
Compound 3: the middle estimate sits 1.2-fold (0.09 log units) below what was measured; measured number inside the range.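

In this assay, replacing the hydrogen atom on this oxygen with the group of 11 heavy atoms, which carries a five-membered non-aromatic ring with 2 hetero atoms, gives a 1.5-fold lower number from compound 1 to compound 3 (0.17 log units; within the scatter). Going by these compounds alone, this is the only measured change at this oxygen, and it shows that a group of this size can stand there while the read-out remains an exact number within the scatter of compound 1, so the substitution leaves no measurable mark in this assay. Within the data shown here, nothing measured so far bears on the cause of this result.

With a single substituent at this oxygen, the share of the five-membered ring with 2 hetero atoms cannot be separated from that of the rest of the group, and a plain hexanoyl group with no sulfur in it would be the direct comparison. As far as these compounds go, it also remains open whether this oxygen tolerates a substituent ending in an amine or a carboxylic acid equally well in this assay.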